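This account rests on a few compounds, and the source may have more. Where it says the series, first, only, none or still open, it means among the compounds named here.

Working notes on the series. Compound 1 `Cc1cc(Cl)cc(-c2ccnc3cc(CN4C(=O)CCC4=O)sc23)c1CN1CCNC[C@@H]1C` is the reference point; in an assay on isolated protein for inhibition of ubiquitin carboxyl-terminal hydrolase 7 (Homo sapiens), read by fluorescence, with stated times of 30 min and 1 h (on this read-out lower numbers stand for stronger inhibition and higher numbers for weaker inhibition), compound 1 gives 6.6 nM, the lowest of the two numbers recorded so far. Going by the values given here, the only other measured member, compound 2 `O=C(C1Cc2cc(Cl)cc(-c3ccnc4[nH]ccc34)c2O1)N1CCNCC1`, gives 930 nM in this assay, a gap well beyond the scatter; the two structures differ in many places, so the numbers show only that compound 1 sits far stronger, not which part of the difference carries it.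

Compound 3 `Cc1cc(Cl)cc(-c2ccnc3cc(CN4C(=O)CCC4=O)sc23)c1CN1[C@@H](C)CNC[C@@H]1C` has not been measured. It differs from compound 1 by methyl in place of hydrogen on a saturated ring carbon. No comparable single change is available among the measured compounds, so the size of the step rests on the change alone: a small effect, likely within the scatter, with a slight lean toward a higher number. The estimate for compound 3 in this assay is 10 nM, with a range from 3 nM to 40 nM, which corresponds to an expected step of a 1.5-fold higher number from compound 1 to compound 3 (0.18 log units; within the scatter).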

Compound 3, half-maximal inhibitory concentration: 0.32 nM
Compound 3: the middle estimate sits 31-fold (1.49 log units) above what was measured; the measured number lies below the stated range.
By their numbers in this assay, from the lowest: compound 3; then compound 1; then compound 2.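

Changing 2-methylpiperazin-1-yl to 2,6-dimethylpiperazin-1-yl gives a 21-fold lower number from compound 1 to compound 3 (1.31 log units; beyond the scatter) in this assay, so this saturated ring carbon, next to the ring nitrogen, is highly sensitive to substitution. The earlier comparison of compound 1 with compound 2 spanned many structural differences and could not be assigned to any one place, whereas this pair ties a large shift to a single added methyl of one heavy atom. Nothing at hand gives a measured basis for the size of this step.

Open, from the compounds shown here alone, is whether ethyl, hydroxymethyl or an aminomethyl group at this carbon would give a number like that of compound 3 or lose the shift. Also open, going by these compounds, is how the other spatial arrangements of the two methyl groups on the ring would compare with compound 3.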